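A few compounds are considered here, and "the series" means these few. Any claim that something is new, unique, unknown or untested is made for them only; others in the source may bear on it.

Working notes on the series. Among the compounds with values here, in an ADME assay on HEK293 cells (Homo sapiens) for cytotoxicity, read by MTT assay, with a stated time of 72 h (on this read-out higher numbers stand for weaker inhibition and lower numbers for stronger inhibition), compound 1 `COc1ccc(C(=O)N2CCN(CC(=O)N3CCN(CCCc4c[nH]c5ccccc45)CC3)CC2)cc1` gives 156000 nM and compound 2 `COc1ccc(C(=O)N2CCN(CC(=O)N3CCN(CCCc4c[nH]c5ccc(OC)cc45)CC3)CC2)cc1` gives 190000 nM, so compound 2 stands within the scatter of compound 1, the only other compound with a number so far.

Compound 3 `COc1ccc2[nH]cc(CCCN3CCN(C(=O)CN4CCN(C(=O)c5cccc(Cl)c5)CC4)CC3)c2c1` carries 3-chlorophenyl in place of 4-methoxyphenyl on a carbonyl carbon. The rest of compound 2 is kept.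

Within the data shown here, the only measured step, a 1.2-fold higher number from compound 1 to compound 2 (0.09 log units; within the scatter), is methoxy in place of hydrogen on an aromatic carbon. Among the measured compounds shown here, it bears on the new change only indirectly, since compound 1 and compound 2 both carry the 4-methoxyphenyl group, and no measured pair varies that group. For the measured compounds named here, with this one small step as the sole guide, no shift beyond the scatter is expected in this assay, and the range is kept wide for the untested change. The estimated step is a 1.1-fold lower number from compound 2 to compound 3 (0.05 log units; within the scatter). Compound 3 is expected at 170000 nM, with an estimated range of 80000 nM to 340000 nM.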

Compound 3, half-maximal inhibitory concentration: 143000 nM
Compound 3: middle estimate off by 1.2-fold (0.08 log units), on the high side, and the stated range covers the measured number.
By their numbers in this assay, from the lowest: compounds 3, 1 and 2 (each within the scatter of the next).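

In this assay, 3-chlorophenyl in place of 4-methoxyphenyl on a carbonyl carbon, whose other neighbour is an amide-type nitrogen in a ring, gives a 1.3-fold lower number from compound 2 to compound 3 (0.12 log units; within the scatter) as the only step shown that varies this aryl group. The exchange replaces 8 heavy atoms with 1 hydrogen-bond acceptor by 7 heavy atoms with no hydrogen-bond acceptor, and the read-out does not separate the two groups beyond the scatter, so this position joins the methoxy change on the shared core, a 1.2-fold higher number from compound 1 to compound 2 (0.09 log units; within the scatter), as a second place where a single change stays within the scatter. No supporting measurement accompanies this step, and its origin cannot be stated.

A single exchange removes the methoxy group and introduces the chlorine together, so the pair cannot show what either change does alone, or whether the place of the substituent on the ring matters. Also open, going by these compounds, is whether an amine or a carboxylic acid on this aromatic ring, or a pyridine ring in its place, would give a step beyond the scatter in this assay.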